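Changing the group on nitrogen: what to expect of compound 4

The compounds below may be only part of what the source reports. "The series", "measured", "known", "first", "only" and "open" are said of these compounds alone.

compound 1 `COc1cc(C(=O)c2cn(-c3ccccc3Cl)cc2-c2ccccc2)cc(OC)c1OC` gives 1800 nM
compound 2 `COc1cccc(-n2cc(C(=O)c3cc(OC)c(OC)c(OC)c3)c(-c3ccccc3)c2)c1` gives 500 nM
compound 3 `COc1cc(C(=O)c2cn(-c3ccc(Br)cc3)cc2-c2ccccc2)cc(OC)c1OC` gives 20 nM

These three compounds were measured in a functional assay on MCF7 cells (Homo sapiens) for cytotoxicity, read by MTT assay, with a stated time of 96 h (on this read-out lower numbers stand for stronger inhibition and higher numbers for weaker inhibition), and differ only in the group on an aromatic nitrogen. Compound 3 has the lowest number of the three, and both steps that reach it are large and beyond the scatter, namely a 90-fold lower number from compound 1 to compound 3 (1.95 log units; beyond the scatter) and a 25-fold lower number from compound 2 to compound 3 (1.40 log units; beyond the scatter).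

The unmeasured compound 4 `COc1cc(C(=O)c2cn(-c3cc(OC)c(OC)c(OC)c3)cc2-c2ccccc2)cc(OC)c1OC` keeps the core of compound 3 and changes that group once more: 3,4,5-trimethoxyphenyl in place of 4-bromophenyl on an aromatic nitrogen. All three measured steps bear on this change, since each swaps the group at this same place. Besides the two large steps, there is a modest one, a 3.6-fold lower number from compound 1 to compound 2 (0.56 log units; beyond the scatter). Neither of the other groups tried so far comes close to the 4-bromophenyl of compound 3, so a large step toward a higher number is expected in this assay. The nearest comparison is compound 2 at 500 nM, which carries 3-methoxyphenyl. Among the compounds with values here, no measured compound carries 3,4,5-trimethoxyphenyl on this nitrogen, so the range must stay wide. The expected change is a 15-fold higher number from compound 3 to compound 4 (1.18 log units; beyond the scatter). For compound 4 the estimated value is 300 nM, with an expected range from 40 nM to 2000 nM.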

Compound 4, half-maximal inhibitory concentration: > 5000 nM
Compound 4 gave a limit, no number; the forecaster's own chance of this, stated with the estimate: 5%; middle value at least 16-fold (1.22 log units) away from the limit.
By their numbers in this assay, from the lowest: compound 3; then compound 2; then compound 1. At a limit, above all of these: compound 4.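

In this assay compound 4 gives > 5000 nM, which is a limit of the assay and not a number. The earlier compounds shown here showed that the group on this nitrogen can move the number a long way, but replacing 4-bromophenyl with 3,4,5-trimethoxyphenyl gives the largest step seen so far, an at least 250-fold higher number from compound 3 to compound 4 (2.39 log units; beyond the scatter). Within the data shown here, the new group also ends up behind both of the weaker groups, with an at least 10-fold higher number from compound 2 to compound 4 (1.00 log units; beyond the scatter) and an at least 2.7-fold higher number from compound 1 to compound 4 (0.44 log units; beyond the scatter), so the single methoxy group of compound 2 gave no sign that a 3,4,5-trimethoxyphenyl group on this nitrogen would push the number higher still.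

The compounds shown leave open whether the bromine itself accounts for the low number of compound 3, which a plain phenyl group on this nitrogen would help to settle. They also leave open how the number would respond to an amine or a carboxylic acid on this ring, and how many of the methoxy groups of compound 4 can be kept before the number climbs.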